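The compounds below may be only part of what the source reports. "The series", "measured", "known", "first", "only" and "open" are said of these compounds alone.

Measured so far in a physicochemical assay for lipophilicity, read by HPLC, with a stated time of 90 min, tested at 100 uM; on this read-out higher numbers stand for higher lipophilicity and lower numbers for lower lipophilicity:
- compound 1 `O=C(Nc1ccc(OC(F)(F)F)cc1)NC1CCN(C(=O)C2CCOCC2)CC1`: 3.26
- compound 2 `CC[C@H](C)C(=O)N1CCC(CC(=O)Nc2ccc(OC(F)(F)F)c(F)c2)CC1`: 7.68

Compound 1 holds the lower of the two numbers, at 3.26. Compound 2 reads 7.68, a gap well beyond the usual scatter. The two compounds differ in more than one place, so this gap gives no size for a single change.

The next compound to be read is compound 3 `O=C(Nc1ccc(OC(F)(F)F)cc1)NC1CCN(C(=O)C2CCOC2)CC1`, which keeps the core of compound 1 and alters one group: oxolan-3-yl in place of oxan-4-yl on a carbonyl carbon. This puts oxolan-3-yl in place of oxan-4-yl on a carbonyl carbon, and the group's hydrogen-bond counts stay the same.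

Within the data shown here, no measured pair shows a comparable exchange, so the expectation rests on the structural change alone, starting from compound 1 at 3.26. A small downward step in this assay is expected, one that stays within the scatter. The estimated step is a number 0.26 log units lower from compound 1 to compound 3 (within the scatter). For compound 3 the expected value is 3, with an estimated range of 2.6 to 3.4.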

Compound 3, partition coefficient: 3.22
Compound 3: the middle estimate sits 0.22 log units below what was measured, within the range that was stated.
By their numbers in this assay, from the lowest: compounds 3 and 1 (each within the scatter of the next); then compound 2.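

In this assay, the series now has its first exchange in a single place: oxolan-3-yl in place of oxan-4-yl on a carbonyl carbon gives a number 0.04 log units lower from compound 1 to compound 3 (within the scatter), so this read-out does not separate the two compounds. Among these compounds, at this position, on a carbonyl carbon whose other neighbours are an amide-type nitrogen in a ring, going from the six-membered ring of 6 heavy atoms to the five-membered ring of 5 heavy atoms, with the hydrogen-bond counts unchanged, leaves no step that stands beyond the scatter. Nothing on hand gives an explanation for this outcome.

The result covers one exchange between two closely related saturated oxygen rings, and steps involving compound 2 cannot be read because that compound differs from the others in more than one place. Still open, on these data alone, is whether a group of another kind on the same carbonyl carbon, such as one bearing an amine or a carboxylic acid, or a longer open chain, would shift the reading in this assay by more than the scatter.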